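The source may report more compounds than this note shows. Statements on the series, on what has been measured and on what is new or still open speak of the compounds shown alone.

Compound 1 `c1cncc(-c2ccccc2OCC2=NCCN2)c1` gives 79.4 nM in a functional assay for activation of Alpha-1B adrenergic receptor (Homo sapiens), read by calcium flux; on this read-out lower numbers stand for an effect already at smaller amounts and higher numbers for an effect only at larger amounts of compound.
Compound 2 `c1ccc(-c2ccncc2)c(OCC2=NCCN2)c1` gives in this assay < 100000 nM, which is a limit of the assay and not a number.
Compound 3 `Cc1ccnc(-c2ccccc2OCC2=NCCN2)c1` gives in this assay < 100000 nM, again a limit of the assay.

Compound 2 therefore stands only at a limit, and its place among the measured compounds cannot be read; the limit of < 100000 nM in this assay, at which 2 of the 3 values shown sit, holds two of the three values. The change to compound 4 `c1cnc(-c2ccccc2OCC2=NCCN2)nc1` is pyrimidin-2-yl in place of pyridin-4-yl on an aromatic carbon. For the measured compounds named here, only one measured step bears on it, a step that the limit leaves unreadable from compound 1 to compound 2, and no measured compound carries a pyrimidin-2-yl group. The expected step is a step that the limit leaves unreadable from compound 2 to compound 4, with no direction readable from the data. Compound 4 is estimated to give 5000 nM, within an expected range from 300 nM to 100000 nM, and a limit is again likely.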

Compound 4, half-maximal effective concentration: < 100000 nM
Compound 4 ended at the assay's limit; the forecaster's own chance of this, stated with the estimate: 60%; the middle value is on the limit's open side.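

No new step can be read from compound 4 to compound 1 or compound 2, because compound 4 gives only a limit of the assay, not a number: the limit of < 100000 nM in this assay, at which 3 of the 4 values shown sit.
The compounds shown leave open whether pyrimidin-2-yl and pyridin-4-yl differ at all in this read-out, and how far compound 2 and compound 4 truly lie from compound 1.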